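The compounds below may be only part of what the source reports. "The series", "measured", "known", "first", "only" and "open" are said of these compounds alone.

Of the compounds shown here, three sharing one core have been measured in a functional assay on Cortex (Rattus norvegicus, strain Sprague-Dawley), read by LDH release; a lower number here means that less compound is needed, a higher number that more compound is needed for the effect. Compound 1 `C/C(=N\c1nc2ccc(OC(F)(F)F)cc2s1)N(C)C` gives 0.1 uM. Compound 2 `CCCNC(=S)Nc1nc2ccc(OC(F)(F)F)cc2s1` carries a thiourea with a propyl chain in place of the amidine-type group of compound 1. Compound 2 gives 0.01 uM, and compound 3 `CC(C)NC(=S)Nc1nc2ccc(OC(F)(F)F)cc2s1`, the isopropyl counterpart, gives 0.01 uM. The two thioureas are alike: no change at the digits printed from compound 2 to compound 3 (within the scatter). Against the amidine both stand well apart, since a 10-fold lower number from compound 1 to compound 2 (1.00 log units; beyond the scatter) and a 10-fold lower number from compound 1 to compound 3 (1.00 log units; beyond the scatter). Compound 2 therefore sits, together with compound 3, at the lowest number of the three, with compound 1 as the furthest.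

Compound 4 `CCCCNC(=S)Nc1nc2ccc(OC(F)(F)F)cc2s1` extends the chain of compound 2 by one carbon: methyl in place of hydrogen on a saturated chain carbon, three bonds along the chain from an amide-type nitrogen. Among the measured compounds shown here, the only measured step that touches the chain alone is the one from propyl to isopropyl, which stayed within the scatter; the two large steps concern the thiourea itself, which compound 4 keeps. Nothing measured speaks to chain length beyond three carbons, so the expectation rests on that single quiet step. Compound 4 is therefore expected to show no change at the digits printed from compound 2 to compound 4 (within the scatter) in this assay, with no change beyond the scatter. The estimate for compound 4 is 0.01 uM, ranging from 0.003 uM to 0.03 uM.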

Compound 4, minimum effective concentration: 0.01 uM
The estimate for compound 4 equals the measured number at the digits printed, within the range that was stated.
By their numbers in this assay, from the lowest: compounds 2, 3 and 4 (each within the scatter of the next); then compound 1.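

In this assay, the methyl added on a saturated chain carbon, three bonds along the chain from an amide-type nitrogen, turns propyl into butyl and gives no change at the digits printed from compound 2 to compound 4 (within the scatter). Among the compounds shown here, this is the first direct look at chain length in the thioureas, and it shows that this position takes the extra carbon with no change that stands out from the scatter, while the straight butyl chain and the branched isopropyl group also stay level, with no change at the digits printed from compound 3 to compound 4 (within the scatter). Nothing available here explains why the number holds steady across these three chains.

The compounds shown leave open how far this tolerance reaches: a longer chain such as octyl, or a ring-bearing group such as benzyl, might hold the number or might move it well away from that of butyl. As far as these compounds go, it is also open whether a chain ending in an amine or a carboxylic acid would behave like butyl, and whether a urea, with oxygen in place of the sulfur, would keep the low number shared by these thioureas.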